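A few compounds are considered here, and "the series" means these few. Any claim that something is new, unique, unknown or untested is made for them only; others in the source may bear on it.

Compound 1 `COc1ccc(S(=O)(=O)N2CCc3cccc(-c4ccc(N)cc4)c32)cc1` carries a 4-aminophenyl group on the shared core. For the measured compounds named here, in a functional assay on KB-VIN10 cells (Homo sapiens) for inhibition, with a stated time of 72 h (a higher number here means a weaker inhibitor, a lower number a stronger inhibitor), compound 1 gives 262 nM, the highest of the three numbers measured so far, and so it is the weakest inhibitor of the set. Compound 2 `COc1ccc(S(=O)(=O)N2CCc3cccc(-c4ccc(F)c(F)c4)c32)cc1` gives 46 nM in this assay, and compound 3 `COc1ccc(S(=O)(=O)N2CCc3cccc(-c4ccc(F)cc4)c32)cc1` gives 94.6 nM. The step of a 5.7-fold lower number from compound 1 to compound 2 (0.76 log units; beyond the scatter) and the step of a 2.8-fold lower number from compound 1 to compound 3 (0.44 log units; beyond the scatter) both show that exchanging the amino group for fluoro lowers the number, and the step of a 2.1-fold higher number from compound 2 to compound 3 (0.31 log units; beyond the scatter) shows that a further fluoro brings a modest additional gain.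

Compound 4 `COc1ccc(S(=O)(=O)N2CCc3cccc(-c4ccccc4)c32)cc1` is the compound in which the amino group of compound 1 is simply taken away: hydrogen in place of amino on an aromatic carbon. Only the change from compound 1 to compound 3 resembles this one, since there too the amino group leaves, but there fluoro enters while here only hydrogen enters. A modest fall in this assay is therefore expected, likely of similar size to, or a little smaller than, the step to compound 3. Compound 4 is expected to give 130 nM in this assay, within a range from 50 nM to 350 nM. That would mean an expected step of a 2.0-fold lower number from compound 1 to compound 4 (0.30 log units; within the scatter).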

Compound 4, half-maximal inhibitory concentration: 107 nM
For compound 4 the middle estimate is 1.2-fold (0.08 log units) above the measured one; the range from low to high includes it.
By their numbers in this assay, from the lowest: compound 2; then compounds 3 and 4 (each within the scatter of the next); then compound 1.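

Taking the amino group away with nothing but hydrogen in its place is enough to lower the number in this assay, with a 2.4-fold lower number from compound 1 to compound 4 (0.39 log units; beyond the scatter), so the earlier fall seen on going to the fluoro compound did not need a fluoro at all. The single fluoro and hydrogen cannot be told apart at this position, since a 1.1-fold higher number from compound 3 to compound 4 (0.05 log units; within the scatter) leaves the two compounds level within the usual scatter. Only the 3,4-difluorophenyl group stands clear of plain phenyl, with a 2.3-fold higher number from compound 2 to compound 4 (0.37 log units; beyond the scatter), so among these compounds a gain over the unsubstituted ring appears only when two fluoro groups are present, and the 4-aminophenyl group is the one change that goes the other way.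

Nothing available explains why the amino group gives a higher number than hydrogen, or why two fluoro groups give a lower one. Still open, on these data alone, is whether other groups at this position, such as a hydroxyl, a methoxy, a chloro or an acetamide, would follow the amino group, match hydrogen or reach the level of the 3,4-difluorophenyl compound.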